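Halogen at the five-membered ring: from chloro toward iodo

The compounds below may be only part of what the source reports. "The series", "measured", "known", "first", "only" and "open" are said of these compounds alone.

Measured so far:
Compound 1 `Cc1cc(C)n2nccc2n1` gives 60 mg/kg in a functional assay on the whole organism with Rattus norvegicus as the target; on this read-out higher numbers stand for an effect only at larger amounts of compound and lower numbers for an effect already at smaller amounts.
Compound 2 `Cc1cc(C)n2ncc(Cl)c2n1` gives 10 mg/kg in this assay.
Compound 3 `Cc1cc(C)n2ncc(Br)c2n1` gives 20 mg/kg in this assay.

Compound 2 holds the lowest number of the three in this assay. Its nearest neighbour is compound 3, separated by a 2.0-fold higher number from compound 2 to compound 3 (0.30 log units; within the scatter), a gap within the scatter; its furthest is compound 1, separated by a 6.0-fold lower number from compound 1 to compound 2 (0.78 log units; beyond the scatter).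

Compound 4 `Cc1cc(C)n2ncc(I)c2n1` has not yet been measured. It differs from compound 2 in one place: iodo in place of chloro on an aromatic carbon.

Going by the values given here, two measured steps bear on this change. Placing chloro on the shared core gave a 6.0-fold lower number from compound 1 to compound 2 (0.78 log units; beyond the scatter), and placing bromo there gave a 3.0-fold lower number from compound 1 to compound 3 (0.48 log units; beyond the scatter). Going from chloro to bromo gave a 2.0-fold higher number from compound 2 to compound 3 (0.30 log units; within the scatter), which stays within the scatter. A halogen at this aromatic carbon thus lowers the number relative to hydrogen, but swapping one halogen for a larger one has not moved it beyond the scatter. Iodo is expected to behave like the other halogens here, with no step beyond the scatter in this assay, or at most a small rise in the number.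

Compound 4 is therefore estimated at 20 mg/kg in this assay, with a range of 8 mg/kg to 50 mg/kg. This estimate means a step of a 2.0-fold higher number from compound 2 to compound 4 (0.30 log units; within the scatter), expected to stay within the scatter.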

Compound 4, minimum effective dose: 120 mg/kg
The estimate for compound 4 lay 6.0-fold (0.78 log units) below the measured number; the whole stated range lies below it.
By their numbers in this assay, from the lowest: compounds 2 and 3 (each within the scatter of the next); then compounds 1 and 4 (each within the scatter of the next).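

In this assay, the three halogens at this aromatic carbon no longer behave as one group: iodo in place of chloro gives a 12-fold higher number from compound 2 to compound 4 (1.08 log units; beyond the scatter) and iodo in place of bromo gives a 6.0-fold higher number from compound 3 to compound 4 (0.78 log units; beyond the scatter), both beyond the scatter, whereas the chloro and bromo compounds lie within the scatter of each other. The gain that chloro and bromo showed over hydrogen is also absent with iodo, since the step of a 2.0-fold higher number from compound 1 to compound 4 (0.30 log units; within the scatter) stays within the scatter, leaving compound 4 level with the unsubstituted compound 1. So having a halogen at this place does not in itself lower the number, and nothing available accounts for why iodo parts from the other two.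

Whether iodo stands alone remains open, as the compounds shown carry no fluoro, methyl, nitrile or amine at this carbon, and the gain over hydrogen rests on chloro and bromo only. They also leave open whether the same halogen steps would hold if a longer chain replaced either methyl group on the shared core.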